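Changing the Group on the Sulfonyl Sulfur: Maximal Response

A few compounds are considered here, and "the series" means these few. Any claim that something is new, unique, unknown or untested is made for them only; others in the source may bear on it.

Three compounds have been measured in a functional assay on HeLa cells for antagonist activity at 5-hydroxytryptamine receptor 6 (Homo sapiens); on this read-out lower numbers stand for smaller maximal responses and higher numbers for larger maximal responses:

Compound 1, `Cc1ccc(S(=O)(=O)c2n[nH]c3ccc(N4CCN(C)CC4)cc23)cc1`, gives 100%.
Compound 2, `CN1CCN(c2ccc3[nH]nc(S(=O)(=O)c4ccccc4Cl)c3c2)CC1`, gives 100%.
Compound 3, `CN1CCN(c2ccc3[nH]nc(S(=O)(=O)c4ccc(Cl)cc4)c3c2)CC1`, gives 100%.

Compound 3 stands level with the other two; its nearest neighbour is compound 1 and its furthest is compound 2, yet neither gap exceeds the usual scatter. All three compounds share one core and differ only in the group attached to the sulfonyl sulfur.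

Compound 4, `CN1CCN(c2ccc3[nH]nc(S(=O)(=O)c4cccs4)c3c2)CC1`, has not been measured. Compared with compound 3 it carries thiophen-2-yl in place of 4-chlorophenyl on a sulfonyl sulfur.

For the measured compounds named here, the steps that bear on this change are the earlier swaps at the same sulfonyl sulfur: no change at the digits printed from compound 1 to compound 2 (within the scatter), no change at the digits printed from compound 1 to compound 3 (within the scatter) and no change at the digits printed from compound 2 to compound 3 (within the scatter). Each of them left the maximal response unchanged within the scatter, although none of them brought in a five-membered ring with a hetero atom. On this basis no step beyond the scatter is expected in this assay; the expected step is no change at the digits printed from compound 3 to compound 4 (within the scatter). Compound 4 is therefore estimated at 100%, with a range from 88% to 110%.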

Compound 4, largest response reached (reported as Imax), in percent of the reference or control that the assay uses: 96%
Compound 4: the middle estimate sits 4 percentage points above what was measured; measured number inside the range.
By their numbers in this assay, from the lowest: compounds 4, 1, 2 and 3 (each within the scatter of the next).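

In this assay, for the compounds shown here, compound 4 is the only one of the four compounds with a five-membered aromatic ring with a hetero atom on the sulfonyl sulfur, so the swap to thiophen-2-yl tests a different kind of ring from the earlier six-membered aromatic rings of carbon only. The maximal response stays within the scatter against every earlier group: a number 4 percentage points lower from compound 3 to compound 4 (within the scatter) and a number 4 percentage points lower from compound 2 to compound 4 (within the scatter) and also a number 4 percentage points lower from compound 1 to compound 4 (within the scatter). Nothing measured here explains why the read-out holds across these groups.

As far as these compounds go, whether an amine, a carboxylic acid or a longer alkyl chain on the sulfonyl sulfur would also hold the maximal response stays open. From the compounds shown here alone, none of the four groups moves the read-out beyond the scatter, so it remains unknown what kind of group at this position could do so.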